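This account rests on a few compounds, and the source may have more. Where it says the series, first, only, none or still open, it means among the compounds named here.

Measured so far in a functional assay on the whole organism (muscle tissue) with Rattus norvegicus as the target; a lower number here means a smaller maximal response, a higher number a larger maximal response:
- compound 1 `CNC(=O)C1=CC(C)(C)Oc2ccc(C#N)cc21`: 66.6%
- compound 2 `CCNC(=O)C1=CC(C)(C)Oc2ccc([N+](=O)[O-])cc21`: 80.5%

Compound 2 stands at the top of the two numbers in this assay, with compound 1 the nearest, lower by an amount beyond the scatter. Compound 1 and compound 2 differ in more than one place, so nothing beyond the two values themselves can be drawn from that pair.

Compound 3 `CCCCNC(=O)C1=CC(C)(C)Oc2ccc([N+](=O)[O-])cc21` has not yet been measured in this assay. Against compound 2 the change is ethyl in place of hydrogen on a saturated chain carbon, two bonds along the chain from an amide-type nitrogen.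

For the measured compounds named here, no step between measured compounds bears on this change. The expectation is a step of modest size, most likely within the scatter and, if anything, slightly downward rather than upward. For compound 3 the estimated value in this assay is 77%, with a range from 62% to 92%. The step this estimate implies, a number 3.5 percentage points lower from compound 2 to compound 3 (within the scatter), is expected to stay within the scatter.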

Compound 3, intrinsic activity: the largest response reached, in percent of the reference agonist's: 83.2%
Estimate against measurement, compound 3: 6.2 percentage points below, within the range that was stated.
By their numbers in this assay, from the lowest: compound 1; then compounds 2 and 3 (each within the scatter of the next).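

In this assay, for the compounds shown here, the replacement of hydrogen by ethyl on a saturated chain carbon, two bonds along the chain from an amide-type nitrogen, gives a number 2.7 percentage points higher from compound 2 to compound 3 (within the scatter) and is the first single-place comparison. The ethylamino and butylamino forms therefore cannot be told apart in this read-out, so the added ethyl has no effect that can be read here. No measurement at hand offers an explanation for this result.

Still open, on these data alone, is whether a longer chain such as hexyl, a branched group such as tert-butyl, or a chain ending in an amine or a carboxylic acid would also stay within the scatter of compound 2. Also open, as far as these compounds go, is what separates compound 1 from compound 2, since methylamino and nitrile have not been compared one at a time with ethylamino and nitro.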